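From 3-Carboxybenzyl to 3,5-Difluorobenzyl on a Shared Core

This account rests on a few compounds, and the source may have more. Where it says the series, first, only, none or still open, it means among the compounds named here.

Compound 3 (`Cn1cc(-c2cnc3[nH]cc(-c4cnn(Cc5cccc(C(=O)O)c5)c4)c3c2)cn1`) gives > 10000 nM in a functional assay on KARPAS-299 cells (Homo sapiens) for cytotoxicity, read by XTT assay, with a stated time of 72 h (on this read-out lower numbers stand for stronger inhibition and higher numbers for weaker inhibition), which is a limit of the assay and not a number. Two relatives bearing a fluorinated benzyl group do give numbers. Compound 1 (`Cn1cc(-c2cnc3[nH]cc(-c4cnn(Cc5ccccc5F)c4)c3c2)cn1`) gives 2090 nM, and compound 2 (`Cn1cc(-c2cnc3[nH]cc(-c4cnn(Cc5ccc(F)cc5)c4)c3c2)cn1`) gives 1780 nM. The step between these two is a 1.2-fold lower number from compound 1 to compound 2 (0.07 log units; within the scatter).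

Compound 4 (`Cn1cc(-c2cnc3[nH]cc(-c4cnn(Cc5cc(F)cc(F)c5)c4)c3c2)cn1`) differs from compound 3 in one place: 3,5-difluorophenyl in place of 3-carboxyphenyl on a saturated chain carbon bound to an aromatic nitrogen. The 3-carboxybenzyl group thus gives way to 3,5-difluorobenzyl, with 3,5-difluorophenyl on a saturated chain carbon bound to an aromatic nitrogen.

Among the compounds with values here, two measured steps bear most directly on this change, and both run towards the carboxylated compound: an at least 4.7-fold higher number from compound 1 to compound 3 (0.67 log units; beyond the scatter) and an at least 5.6-fold higher number from compound 2 to compound 3 (0.74 log units; beyond the scatter). Read in reverse, they suggest that leaving the 3-carboxyphenyl group should bring a lower number, of at least modest size and beyond the scatter. Within the data shown here, no measured compound carries two fluorines on the benzyl group, so the estimate rests on the two singly fluorinated relatives, and its range is kept wide.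

The estimated step is an at least 5.5-fold lower number from compound 3 to compound 4 (0.74 log units; beyond the scatter). For compound 4 the expected value is 1800 nM, with an estimated range from 700 nM to 4500 nM.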

Compound 4, half-maximal inhibitory concentration: 664 nM
Estimate against measurement, compound 4: 2.7-fold (0.43 log units) above, and the stated range ends above it.
By their numbers in this assay, from the lowest: compound 4; then compounds 2 and 1 (each within the scatter of the next). At a limit, above all of these: compound 3.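

In this assay, the singly fluorinated compounds 1 and 2 lie within the scatter of each other, but the 3,5-difluorophenyl group on a saturated chain carbon bound to an aromatic nitrogen separates from both, with a 2.7-fold lower number from compound 2 to compound 4 (0.43 log units; beyond the scatter) and a 3.1-fold lower number from compound 1 to compound 4 (0.50 log units; beyond the scatter). Compound 4 thus has the lowest number of the four, and the fluorinated benzyl groups at this position no longer form a single level, as compounds 1 and 2 alone had suggested. The step out of the 3-carboxyphenyl group, an at least 15-fold lower number from compound 3 to compound 4 (1.17 log units; beyond the scatter), starts from a limit and not from a number: the limit of > 10000 nM in this assay, at which 1 of the 4 values shown sits.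

The compounds shown leave open how an unsubstituted benzyl group would compare with the fluorinated ones, and so whether fluorine on the benzyl group lowers the number at all or whether only the 3,5-difluorobenzyl pattern does. They also leave open whether a methyl ester or a primary amide in place of the carboxylic acid would stay at the limit reached by compound 3 or return to the range of compounds 1, 2 and 4.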